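The compounds below may be only part of what the source reports. "The series", "measured", "known", "first", "only" and "open" are said of these compounds alone.

Measured so far in a functional assay on HCT-116 cells (Homo sapiens) for antiproliferative activity, read by MTT assay, with a stated time of 72 h; a higher number here means a weaker inhibitor, a lower number a stronger inhibitor:
- compound 1 `Cc1ccc(N2CCN(C(=S)SCc3ccc4nc(N)nc(N)c4c3)CC2)cc1` gives 5510 nM
- compound 2 `Nc1nc(N)c2cc(CSC(=S)N3CCN(c4ccc(Cl)cc4)CC3)ccc2n1` gives 7380 nM
- compound 3 `Nc1nc(N)c2cc(CSC(=S)N3CCN(c4ccccc4F)CC3)ccc2n1` gives "not determined" (no result reported)

Compound 2, at 7380 nM in this series, lies within the scatter of compound 1, and compound 3 offers no number for comparison. In compound 4 `Nc1nc(N)c2cc(CSC(=S)N3CCN(c4ccccc4[N+](=O)[O-])CC3)ccc2n1`, 2-nitrophenyl stands in place of 4-chlorophenyl on an amine nitrogen in a ring (2-nitrophenyl in place of 4-chlorophenyl on an amine nitrogen in a ring). Among the compounds with values here, only one measured step bears on this place: a 1.3-fold higher number from compound 1 to compound 2 (0.13 log units; within the scatter) put chloro in place of methyl on an aromatic carbon and stayed within the scatter. Within the data shown here, no measured compound carries a nitro group, so the data give no direction, and no step beyond the scatter is expected in this assay. The estimated change is a 1.1-fold lower number from compound 2 to compound 4 (0.06 log units; within the scatter) and remains uncertain. Compound 4 is expected at 6500 nM with an estimated range of 2200 nM to 19000 nM in this assay.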

Compound 4, half-maximal inhibitory concentration: 5520 nM
Compound 4: middle estimate off by 1.2-fold (0.07 log units), on the high side, and the stated range covers the measured number.
By their numbers in this assay, from the lowest: compounds 1, 4 and 2 (each within the scatter of the next).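

In this assay, 2-nitrophenyl in place of 4-chlorophenyl on the amine nitrogen in a ring gives a 1.3-fold lower number from compound 2 to compound 4 (0.13 log units; within the scatter), and 2-nitrophenyl in place of 4-methylphenyl gives a 1.0-fold higher number from compound 1 to compound 4 (0.00 log units; within the scatter). Across compounds 1, 2 and 4, this place therefore takes a nitro group as well as chloro or methyl, with no step beyond the scatter. No evidence on the cause of this result is available. Going by these compounds, whether a carboxylic acid or an amine on this aromatic ring would give a step beyond the scatter remains open.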